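Carboxyfuran in Place of Thiophene on the Biaryl Arm

The source may report more compounds than this note shows. Statements on the series, on what has been measured and on what is new or still open speak of the compounds shown alone.

Three compounds have been measured in an assay on isolated protein for inhibition of ubiquitin carboxyl-terminal hydrolase 7 (Homo sapiens), with stated times of 30 min and 2 h; a lower number here means a stronger inhibitor, a higher number a weaker inhibitor:
Compound 1 `Cn1nc2c(=O)n(CC3(O)CCN(Cc4ccc(-c5cccs5)cc4Cl)CC3)cnc2c1-c1ccc(CN)cc1` gives 38.6 nM.
Compound 2 `CC(C)NCc1ccc(-c2c3ncn(CC4(O)CCN(Cc5ccc(-c6ccco6)cc5Cl)CC4)c(=O)c3nn2C)cc1` gives 29.1 nM.
Compound 3 `CCCNCc1ccc(-c2c3ncn(CC4(O)CCN(Cc5ccc(-c6ccco6)cc5Cl)CC4)c(=O)c3nn2C)cc1` gives 43.9 nM.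

The three numbers lie close together. Compound 1 sits between the other two, and its gaps to compound 3 and to compound 2 are both within the scatter, so no order among the three can be claimed. Going by the values given here, the one step between compounds that differ in a single place, a 1.5-fold higher number from compound 2 to compound 3 (0.18 log units; within the scatter), concerns the amine nitrogen and is itself within the scatter.

Compound 4 `Cn1nc2c(=O)n(CC3(O)CCN(Cc4ccc(-c5ccc(C(=O)O)o5)cc4Cl)CC3)cnc2c1-c1ccc(CN)cc1` has not yet been measured in this assay. It differs from compound 1 in one place: 5-carboxyfuran-2-yl in place of thiophen-2-yl on an aromatic carbon. Among the compounds with values here, no measured step touches this position, and the one step that exists, between compound 2 and compound 3, changes a different part of the molecule. There is therefore nothing in the measured data that points to a shift in either direction, and the expectation rests on the closeness of all three values. Compound 4 is expected to give 45 nM, with a range from 15 nM to 140 nM. That estimate means a step of a 1.2-fold higher number from compound 1 to compound 4 (0.07 log units; within the scatter), which is expected to stay within the scatter.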

Compound 4, half-maximal inhibitory concentration: 753 nM
For compound 4 the middle estimate is 17-fold (1.22 log units) below the measured one, and the stated range ends below it.
By their numbers in this assay, from the lowest: compounds 2, 1 and 3 (each within the scatter of the next); then compound 4.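

Going by these compounds alone, the step of a 20-fold higher number from compound 1 to compound 4 (1.29 log units; beyond the scatter) in this assay shows that this aromatic carbon, meta to a chloro group and para to a large group, does not tolerate every five-membered aromatic ring, whereas the only earlier step, a 1.5-fold higher number from compound 2 to compound 3 (0.18 log units; within the scatter), concerned the amine nitrogen and stayed within the scatter. The exchange alters several things at once: sulfur gives way to oxygen in the ring, the heavy-atom count of the group rises, and the entering 5-carboxyfuran-2-yl carries a hydrogen-bond donor that thiophen-2-yl lacks. Nothing available explains why the number rises this far at this position.

The compounds shown do not separate the ring exchange from the added carboxylic acid: compound 2 and compound 3 carry an unsubstituted furan at this place, but they also differ from compound 1 at the amine nitrogen. Furan-2-yl with the primary aminomethyl group of compound 1, a thiophene bearing the carboxylic acid, and a methyl ester or primary amide in place of that acid remain open as ways to tell which part of the change goes with the step.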